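The source may hold more compounds than are shown below. What is called first, only, known or untested is meant among the compounds shown, and "the series" means these compounds.

Measured so far in a functional assay on HT-1080 cells (Homo sapiens) for cytotoxicity, read by MTT assay, with a stated time of 72 h; a higher number here means a weaker inhibitor, a lower number a stronger inhibitor:
- compound 1 `COc1cccc(/C=C2\CCC/C(=C\c3ccc(Cl)cc3)C2=O)c1OC` gives 11100 nM
- compound 2 `COc1cccc(/C=C2\CCC/C(=C\c3cccc(OC)c3OC)C2=O)c1` gives 9900 nM
- compound 3 `COc1ccc(/C=C2\CCC/C(=C\c3ccccc3Br)C2=O)cc1OC` gives 8400 nM

Among the compounds with values here, compound 3 at 8400 nM stands within the scatter of both compound 1 and compound 2, so these three numbers set up no order among the compounds. The next compound is compound 4 `COc1ccc(/C=C2\CCC/C(=C\c3cccc(Cl)c3Cl)C2=O)cc1OC` and the change leading to it is 2,3-dichlorophenyl in place of 2-bromophenyl on a double-bonded chain carbon bound to a double-bonded ring carbon with 2,3-dichlorophenyl in place of 2-bromophenyl on a double-bonded chain carbon bound to a double-bonded ring carbon.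

Within the data shown here, only one measured step bears on this change. The step of a 1.1-fold lower number from compound 1 to compound 2 (0.05 log units; within the scatter) falls at the same kind of place, with 3-methoxyphenyl in place of 4-chlorophenyl, and it stays within the scatter. Among the measured compounds shown here, no measured pair removes 2-bromophenyl or brings in 2,3-dichlorophenyl, so the evidence is thin. Even so, nothing in the three numbers points to a large move, and in this assay no shift beyond the scatter is expected in either direction. The expected step is a 1.1-fold lower number from compound 3 to compound 4 (0.02 log units; within the scatter) and it would remain within the scatter. For compound 4 the estimated value is 8000 nM with an expected range from 4000 nM to 15000 nM on this reading.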

Compound 4, half-maximal inhibitory concentration: 8800 nM
For compound 4 the middle estimate is 1.1-fold (0.04 log units) below the measured one, and the stated range covers the measured number.
By their numbers in this assay, from the lowest: compounds 3, 4, 2 and 1 (each within the scatter of the next).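

In this assay, the exchange of 2-bromophenyl for 2,3-dichlorophenyl on a double-bonded chain carbon bound to a double-bonded ring carbon gives a 1.0-fold higher number from compound 3 to compound 4 (0.02 log units; within the scatter). Within the data shown here, this is the first direct reading of a halogen-bearing phenyl group exchanged for another at this place, and it shows that replacing the single bromine with two chlorines, a gain of one heavy atom overall, produces no shift beyond the scatter, in line with the other measured exchange at this kind of place, a 1.1-fold lower number from compound 1 to compound 2 (0.05 log units; within the scatter). Nothing measured here accounts for this lack of a shift.

Both steps exchange one substituted phenyl group for another, so they cover only a narrow range of groups at this place, and all four numbers remain within the scatter of their neighbours in the ordering. As far as these compounds go, it remains open whether an amine or a carboxylic acid on the phenyl group, or a longer chain in place of that group, would move the number in this assay beyond the scatter in either direction.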